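The source may hold more compounds than are shown below. What is called first, only, known or untested is meant among the compounds shown, and "the series" means these compounds.

Measured compounds:
compound 1 `CCn1c(C(=O)NCC(=O)OC)ccc1C(CC)(CC)c1ccc(OCS(=O)(=O)c2ccccc2)c(C)c1` — > 50000 nM
compound 2 `CCn1c(C(=O)N[C@@H](C)CO)ccc1C(CC)(CC)c1ccc(OCS(=O)(=O)c2ccccc2)c(C)c1` — 10800 nM
compound 3 `CCn1c(C(=O)N[C@H](CO)CCO)ccc1C(CC)(CC)c1ccc(OCS(=O)(=O)c2ccccc2)c(C)c1` — 28500 nM

In a functional assay on MCF7 cells (Homo sapiens) for antiproliferative activity, read by MTT assay, with a stated time of 24 h (on this read-out lower numbers stand for stronger inhibition and higher numbers for weaker inhibition), compound 1 returns only a limit, > 50000 nM, so its true position is not known; it sits at the limit of > 50000 nM in this assay, at which 1 of the 3 values shown sits. Compound 2 gives 10800 nM in this assay, and compound 3 gives 28500 nM. Both carry a hydroxyl-bearing group on the amide-type nitrogen where compound 1 carries a (methoxycarbonyl)methyl, and both read lower than the limit of compound 1: an at least 4.6-fold lower number from compound 1 to compound 2 (0.66 log units; beyond the scatter) and an at least 1.7-fold lower number from compound 1 to compound 3 (0.24 log units; that floor lies within the scatter). Between the two measured analogues, a 2.6-fold higher number from compound 2 to compound 3 (0.42 log units; beyond the scatter).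

Compound 4 `CCn1c(C(=O)N[C@H](C(=O)O)C(C)C)ccc1C(CC)(CC)c1ccc(OCS(=O)(=O)c2ccccc2)c(C)c1` is the next step from compound 1. The change is 1-carboxy-2-methylpropyl in place of (methoxycarbonyl)methyl on an amide-type nitrogen. Within the data shown here, no measured step exchanges the ester for a carboxylic acid, so the two steps from compound 1 are the only guide: each departure from the (methoxycarbonyl)methyl lowered the number, one by a modest amount and one by an amount whose floor lies within the scatter. The acid of compound 4 is therefore expected to move the number down from the limit of compound 1, but only modestly and with real uncertainty as to whether a number rather than a limit appears. Compound 4 is estimated at 20000 nM, between 5000 nM and 60000 nM, meaning an at least 2.5-fold lower number from compound 1 to compound 4 (0.39 log units; beyond the scatter) is expected.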

Compound 4, half-maximal inhibitory concentration: 24500 nM
Compound 4: middle estimate off by 1.2-fold (0.09 log units), on the low side; the measured number falls inside the stated range.
By their numbers in this assay, from the lowest: compound 2; then compounds 4 and 3 (each within the scatter of the next). At a limit, above all of these: compound 1.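

In this assay, the step to 1-carboxy-2-methylpropyl is an at least 2.0-fold lower number from compound 1 to compound 4 (0.30 log units; that floor lies within the scatter), so a group bearing a carboxylic acid rather than a hydroxyl also gives a measured number at this position, though the floor of that step does not establish a real gain. Among the measured groups on the amide-type nitrogen, a 1.2-fold lower number from compound 3 to compound 4 (0.07 log units; within the scatter) places the acid level with 3-hydroxy-1-(hydroxymethyl)propyl, while a 2.3-fold higher number from compound 2 to compound 4 (0.36 log units; beyond the scatter) leaves 1-(hydroxymethyl)ethyl, the group of compound 2, with the lowest number of the series. Compound 1 remains a limit, so the true size of any step from it stays unknown: the limit of > 50000 nM in this assay, at which 1 of the 4 values shown sits.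

The compounds shown leave open whether the carboxylic acid or the branched chain of 1-carboxy-2-methylpropyl sets the number of compound 4, a question that a carboxymethyl group or the methyl ester of the same group would separate. As far as these compounds go, how an amine or a longer hydroxyalkyl chain on this nitrogen would read also remains open.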